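A few compounds are considered here, and "the series" means these few. Any claim that something is new, unique, unknown or untested is made for them only; others in the source may bear on it.

Measured so far in a functional assay on KB cells (Homo sapiens) for cytotoxicity; a higher number here means a weaker inhibitor, a lower number a stronger inhibitor:
Compound 1 `C=CCn1cc(C(N)=S)c2c(N)ncnc21` gives 19000 nM.
Compound 2 `COCCOCn1cc(C#N)c2c(N)ncnc21` reaches only the limit of the assay, > 100000 nM.
Compound 3 `C=CCn1cc(C#N)c2c(N)ncnc21` likewise reaches only the limit of the assay, > 100000 nM.

From the compounds shown here alone, compound 3 thus stands at the limit, where two of the three values sit (the limit of > 100000 nM in this assay, at which 2 of the 3 values shown sit), so its true number is unknown and it cannot be ranked against the others. Compound 4 `CCOCn1cc(C#N)c2c(N)ncnc21` differs from compound 3 by ethoxy in place of vinyl on a saturated chain carbon bound to an aromatic nitrogen. Among the measured compounds shown here, the only measured step at this same place, a step that the two limits leave unreadable from compound 2 to compound 3, runs between two limits and offers no readable size, while an at least 5.2-fold higher number from compound 1 to compound 3 (0.72 log units; beyond the scatter) alters a different part of the shared core and says nothing about this position. The expectation for compound 4 is therefore a step that the limit leaves unreadable from compound 3 to compound 4 with no readable direction, most likely ending again at the limit. Compound 4 is estimated at 150000 nM, within a range from 60000 nM to 400000 nM.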

Compound 4, half-maximal inhibitory concentration: > 100000 nM
Compound 4: only a limit was reported (the forecaster's own chance of this, stated with the estimate: 80%); the middle value is on the limit's open side.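

Compound 4 ends at a limit, as do compound 2 and compound 3, so no step among these three can be read. From the compounds shown here alone, whether ethoxy, vinyl or 2-methoxyethoxy at this place changes the true number stays open.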